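The compounds below may be only part of what the source reports. "The series", "measured", "known", "first", "only" and "open" are said of these compounds alone.

Working notes on the series.

The shared core, seen in compound 1 `Cc1ccc2cc(CN(Cc3ccc(F)cc3)Cc3ccc(C(C)(C)C)cc3)c(=O)[nH]c2c1`, compound 2 `Cc1ccc2cc(CN(Cc3ccc(F)cc3)Cc3ccc(C(F)(F)F)cc3)c(=O)[nH]c2c1` and compound 3 `COc1ccc(CN(Cc2ccc(C(C)(C)C)cc2)Cc2cc3cc(C)ccc3[nH]c2=O)cc1`, is read in a toxicity assay on MDCK cells (Canis lupus familiaris) for cytotoxicity, read by crystal violet staining, with a stated time of 48 h; a lower number here means that less compound is tolerated, a higher number that more compound is tolerated. Compound 1 gives only a limit of the assay, > 33000 nM. Compound 2 likewise gives only a limit, > 33000 nM. Compound 3 also reaches no number but only a limit, > 10000 nM. Among the measured compounds shown here, the one comparable step between measured compounds, a step that the two limits leave unreadable from compound 1 to compound 2, cannot be sized, since both ends sit on a limit; this follows from the limit of > 33000 nM in this assay, at which 2 of the 3 values shown sit. Compound 3 stands on a lower limit than the other two, (the limit of > 10000 nM in this assay, at which 1 of the 3 values shown sits), so its place relative to compound 1 and compound 2 is not readable either.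

Compound 4 `Cc1ccc2[nH]c(=O)c(CN(Cc3ccc(C(C)(C)C)cc3)Cc3ccc(N(C)C)c(Cl)c3)cc2c1` is not yet measured in this assay. It differs from compound 3 in one place: 3-chloro-4-(dimethylamino)phenyl in place of 4-methoxyphenyl on a saturated chain carbon bound to an amine nitrogen. For the measured compounds named here, no measured step bears on this change; the only measured step, between compound 1 and compound 2, concerns a different group and is itself unreadable. The three measured values, all limits, give no reason to expect any step beyond the scatter in this assay, and compound 4 is therefore expected to land near the limits as well, a step that the limit leaves unreadable from compound 3 to compound 4.

Compound 4 is estimated at 33000 nM, with a range from 10000 nM to 100000 nM, and most likely reported only as a limit.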

Compound 4, half-maximal cytotoxic concentration: > 10000 nM
Compound 4: a limit, no number (the forecaster's own chance of this, stated with the estimate: 75%); the middle value is on the limit's open side.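

In this assay compound 4 gives only a limit, > 10000 nM. Compound 3 also gives only a limit, > 10000 nM, so no step between compound 3 and compound 4 can be read: the limit of > 10000 nM in this assay, at which 2 of the 4 values shown sit.

The compounds shown leave open at what concentration any of them reaches a half-maximal cytotoxic effect, and whether 3-chloro-4-(dimethylamino)phenyl in place of 4-methoxyphenyl shifts it at all.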